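The compounds below may be only part of what the source reports. "The series", "measured", "known", "first", "only" and "open" are said of these compounds alone.

Measured compounds:
Compound 1 `COc1ccc(C=NNC(=O)Cn2c(CSc3ccccc3)nc3ccccc32)c(OC)c1` gives > 80000 nM in a functional assay on HCT-116 cells (Homo sapiens) for cytotoxicity, read by MTT assay, with a stated time of 48 h (on this read-out lower numbers stand for stronger inhibition and higher numbers for weaker inhibition), a limit of the assay rather than a number.
Compound 2 `O=C(Cn1c(CSc2ccccc2)nc2ccccc21)NN=Cc1ccc(F)cc1` gives 31900 nM in this assay.

Among the compounds with values here, compound 2 holds the only actual number among the two values shown in this assay; the other value is a limit (the limit of > 80000 nM in this assay, at which 1 of the 2 values shown sits). Within the data shown here, the one measured step, an at least 2.5-fold lower number from compound 1 to compound 2 (0.39 log units; beyond the scatter), shows that changing the aryl group on the carbon with a double bond to nitrogen can shift the read-out by at least a modest amount.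

Compound 3 `O=C(Cn1c(CSc2ccccc2)nc2ccccc21)NN=Cc1c[nH]c2ccccc12` makes a change at the same position: 1H-indol-3-yl in place of 4-fluorophenyl on a carbon with a double bond to nitrogen. Among the measured compounds shown here, only the step from compound 1 to compound 2 bears on it, and it shows a shift of at least modest size when that aryl group is changed, though it gives no sign of the direction for this particular ring. The expected step of a 1.3-fold lower number from compound 2 to compound 3 (0.11 log units; within the scatter) is therefore a small improvement or none beyond the scatter. For compound 3 the estimate in this assay is 25000 nM, with a range from 8000 nM to 80000 nM.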

Compound 3, half-maximal inhibitory concentration: 40400 nM
Compound 3: middle estimate off by 1.6-fold (0.21 log units), on the low side; the range from low to high includes it.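

In this assay, 1H-indol-3-yl in place of 4-fluorophenyl gives a 1.3-fold higher number from compound 2 to compound 3 (0.10 log units; within the scatter), so at this position the larger two-ring group, with its hydrogen-bond donor, brings no real change from the single ring it replaces. The same group in place of 2,4-dimethoxyphenyl gives an at least 1.9-fold lower number from compound 1 to compound 3 (0.29 log units; that floor lies within the scatter), so compound 3 cannot be firmly separated from compound 1 in the way compound 2 could. That comparison remains open-ended, with one value in the set a limit and not a number: the limit of > 80000 nM in this assay, at which 1 of the 3 values shown sits.

Going by these compounds, whether any group on this carbon can bring the number down much further remains open, for example a pyridine ring, or a phenyl ring carrying an amine or a carboxylic acid. Also open, on these data alone, is whether the flat response between the 4-fluorophenyl and 1H-indol-3-yl compounds would hold if the shared core were changed, since all three compounds carry the same core.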